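The source may report more compounds than this note shows. Statements on the series, on what has been measured and on what is new or still open speak of the compounds shown alone.

Measured compounds:
compound 1 `Cc1ccc(Oc2cc(F)ccc2CN(C)C)c(N)c1` with 960 nM
compound 2 `Cc1ccc(Oc2ccc(F)cc2CN(C)C)c(N)c1` with 503 nM

Of the compounds shown here, two have been measured in an assay on HEK293 cells for displacement of a labelled ligand from sodium-dependent dopamine transporter (Homo sapiens); a lower number here means a stronger inhibitor, a higher number a weaker inhibitor. Compound 1 gives 960 nM, and compound 2 gives 503 nM. Compound 1 has the highest of the two numbers, but its nearest neighbour, compound 2, differs from it by a gap that lies within the scatter of this assay, so the two compounds cannot be put in an order on these data.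

The unmeasured compound 3 `Cc1ccc(Oc2cc(OCCF)ccc2CN(C)C)c(N)c1` is reached from compound 1 by one change: 2-fluoroethoxy in place of fluoro on an aromatic carbon. The group sits on an aromatic carbon of a six-membered aromatic ring of carbon only, para to a (dimethylamino)methyl group, and the rest of the structure is kept. For the measured compounds named here, no measured pair in this set shows what such a change does in this assay, so the expectation for compound 3 rests on the two values alone. Both measured numbers lie close together, and compound 3 is expected to stay near them. The step from compound 1 is estimated at a 1.3-fold lower number from compound 1 to compound 3 (0.11 log units; within the scatter), a size that does not exceed the scatter. For compound 3 the expected value in this assay is 750 nM, with a range from 250 nM to 2500 nM.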

Compound 3, inhibition constant: 726 nM
The estimate for compound 3 lay 1.0-fold (0.01 log units) above the measured number, within the range that was stated.
By their numbers in this assay, from the lowest: compounds 2, 3 and 1 (each within the scatter of the next).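

For the compounds shown here, at the aromatic carbon para to the (dimethylamino)methyl group, compound 1 and compound 3 form the first pair in this set that differs in one place, and it gives the first direct reading of a change at this position in this assay: 2-fluoroethoxy in place of fluoro gives a 1.3-fold lower number from compound 1 to compound 3 (0.12 log units; within the scatter). The assay therefore does not separate the two compounds, even though the entering group has 4 heavy atoms and 1 hydrogen-bond acceptor, whereas the leaving fluoro has 1 heavy atom and 0 hydrogen-bond acceptors. Nothing in the data given bears on why the two compounds read alike.

The compounds shown leave open whether this position would give a similar reading with an amine, a carboxylic acid or a longer chain, and whether an ethoxy group without the terminal fluorine would read the same as 2-fluoroethoxy. They also leave open whether 2-fluoroethoxy in place of the fluoro of compound 2 would give a comparable step, since a single pair speaks for only one position on the shared core.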